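Triazole in Place of Pyridyl on a Urea Scaffold

The source may report more compounds than this note shows. Statements on the series, on what has been measured and on what is new or still open speak of the compounds shown alone.

Measured so far:
Compound 1: `Cc1cc(C)c(NC(=O)N(Cc2ccccc2)Cc2cccc(-c3cc[nH]n3)c2)c(C)c1` — > 1 mg/kg
Compound 2: `Cc1cc(C)c(NC(=O)N(Cc2ccc(-c3cccnc3)cc2)C2CCCCCC2)c(C)c1` — 0.58 mg/kg

Of the compounds shown here, two have been tested in a functional assay on a cell-free system (plasma) with sterol O-acyltransferase, Soat (Rattus norvegicus) as the target; a lower number here means that less compound is needed, a higher number that more compound is needed for the effect. Compound 1 gives only a limit there: its result of > 1 mg/kg marks the edge of what the assay reports, not a number. Compound 2, by contrast, gives a proper value of 0.58 mg/kg in this assay. That leaves compound 2 holding the only numeric result in the set, while the other entry is the limit of > 1 mg/kg in this assay, at which 1 of the 2 values shown sits. Among the measured compounds shown here, compound 1 and compound 2 differ in several places at once, so no single step between them can be read off.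

Compound 3 is `Cc1cc(C)c(NC(=O)N(Cc2ccc(-n3ccnn3)cc2)C2CCCCCC2)c(C)c1`. Its structure matches compound 2 except for one change: 1H-1,2,3-triazol-1-yl in place of pyridin-3-yl on an aromatic carbon. For the measured compounds named here, no single-point step has been measured in this assay. There is no direct guide to how large an effect to expect. The step from compound 2 to compound 3 is expected to be small, roughly within the usual scatter, and is estimated as a 1.4-fold higher number from compound 2 to compound 3 (0.14 log units; within the scatter). Compound 3 is accordingly expected to come in at about 0.8 mg/kg, somewhere between 0.3 mg/kg and 2.5 mg/kg, with a real chance that the assay again returns only a limit.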

Compound 3, dose for half-maximal effect: > 1 mg/kg
Compound 3: only a limit was reported; the forecaster's own chance of this, stated with the estimate: 35%; at least 1.2-fold (0.09 log units) between middle value and limit.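

In this assay, among the compounds shown here, the swap of pyridin-3-yl for 1H-1,2,3-triazol-1-yl on an aromatic carbon para to a large group is the one change that can be read, and compound 3 gives > 1 mg/kg, which is a limit of the assay and not a number. Read as a floor, this change gives an at least 1.7-fold higher number from compound 2 to compound 3 (0.23 log units; that floor lies within the scatter), so the triazole shows no gain over pyridin-3-yl at this position, although the floor alone cannot separate the two groups. The true size of the step may lie within the scatter or well beyond it, since the result for compound 3 joins that of compound 1 at the edge of what the assay reports: the limit of > 1 mg/kg in this assay, at which 2 of the 3 values shown sit.

The compounds shown leave open whether a plain phenyl ring, a pyridin-4-yl group or a dimethylamino group on this aromatic carbon would keep the value of compound 2. Steps to compound 1 cannot be read, as it differs from the other two compounds in several places at once.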